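This account rests on a few compounds, and the source may have more. Where it says the series, first, only, none or still open, it means among the compounds named here.

Going by the values given here, in a functional assay on HCT-116 cells (Homo sapiens) for inhibition, read by MTT assay, with a stated time of 2 days (on this read-out higher numbers stand for weaker inhibition of growth and lower numbers for stronger inhibition of growth), compound 1 (`Nc1ccccc1NC(=O)c1ccc(NCC(=O)Nc2ccc([N+](=O)[O-])cc2)cc1`) gives 600 nM, the lower of the two numbers measured so far. Compound 2 (`Nc1ccccc1NC(=O)CCCNCC(=O)Nc1cc(Cl)ccc1Cl`) gives 31000 nM, a gap beyond the scatter. These two compounds differ in more than one place, however, so their gap does not isolate any single group. Compound 3 (`Nc1ccccc1NC(=O)c1ccc(NCC(=O)Nc2ccc(Cl)cc2)cc1`) keeps the core of compound 1 and carries chloro in place of nitro on an aromatic carbon, para to a large group: chloro in place of nitro on an aromatic carbon. The same difference reads as 4-nitrophenyl to 4-chlorophenyl. Among the compounds with values here, no measured pair shows this change, so the expectation starts from compound 1 at 600 nM. Only a small rise in the number, within the scatter, is expected: a 1.5-fold higher number from compound 1 to compound 3 (0.18 log units; within the scatter). The estimate for compound 3 is 900 nM, with an expected range from 300 nM to 2700 nM.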

Compound 3, concentration for 50% growth inhibition: 4200 nM
Estimate against measurement, compound 3: 4.7-fold (0.67 log units) below, and the stated range ends below it.
By their numbers in this assay, from the lowest: compound 1; then compound 3; then compound 2.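

On the shared core, the group on this aromatic carbon, para to a large group, clearly affects the result: in this assay chloro in place of nitro gives a 7.0-fold higher number from compound 1 to compound 3 (0.85 log units; beyond the scatter) and the step lies beyond the scatter. Compound 1 and compound 3 differ in this one place, so this change can be read on its own, which the earlier pair of compounds did not allow. Nothing measured here explains the step.

The compounds shown compare only nitro and chloro at this position, so it remains open how a nitrile, a methoxy group or an amine there would read. It is also unknown whether chloro in place of nitro would give a step of similar size on a different core.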